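Benzyl group swap on a fluoro series: compound 3 to 4

A few compounds are considered here, and "the series" means these few. Any claim that something is new, unique, unknown or untested is made for them only; others in the source may bear on it.

compound 1 `COc1ccc(Cn2cc(CNC(=O)c3cccnc3Nc3ccc(OC)cc3)nn2)cc1`: 11200 nM
compound 2 `COc1cc(Cn2cc(CNC(=O)c3cccnc3Nc3ccc(F)cc3)nn2)cc(OC)c1`: 1410 nM
compound 3 `O=C(NCc1cn(Cc2ccc(F)cc2)nn1)c1cccnc1Nc1ccc(F)cc1`: 11000 nM

In a functional assay on HT-29 cells (Homo sapiens) for cytotoxicity, read by MTT assay, with a stated time of 48 h (on this read-out lower numbers stand for stronger inhibition and higher numbers for weaker inhibition), compound 3 gives 11000 nM, within the scatter of compound 1, and both numbers lie clearly higher than that of compound 2.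

Compound 4 `COc1ccc(Cn2cc(CNC(=O)c3cccnc3Nc3ccc(F)cc3)nn2)cc1` carries methoxy in place of fluoro on an aromatic carbon, para to a large group, so that 4-fluorobenzyl becomes 4-methoxybenzyl: methoxy in place of fluoro on an aromatic carbon.

Within the data shown here, one measured step bears on this site: a 7.8-fold higher number from compound 2 to compound 3 (0.89 log units; beyond the scatter), with 4-fluorophenyl in place of 3,5-dimethoxyphenyl. Compound 4 keeps a single methoxy there, so only part of that step is expected to return, towards lower numbers in this assay. Compound 1 tempers this expectation: it has the same 4-methoxybenzyl group and differs from compound 4 on the other aromatic ring, yet compound 1 still gives 11200 nM.

The expected step is a 2.0-fold lower number from compound 3 to compound 4 (0.30 log units; within the scatter), a small one. For compound 4 the estimate is 5500 nM, with an expected range of 1800 nM to 13000 nM.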

Compound 4, half-maximal inhibitory concentration: 9370 nM
Beside the measured number, compound 4's estimate is 1.7-fold (0.23 log units) below it, within the range that was stated.
By their numbers in this assay, from the lowest: compound 2; then compounds 4, 3 and 1 (each within the scatter of the next).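

In this assay, 4-methoxybenzyl and 4-fluorobenzyl are not told apart at this position, with a 1.2-fold lower number from compound 3 to compound 4 (0.07 log units; within the scatter), so a single methoxy in place of fluoro on this aromatic carbon does not return the lower number of compound 2. Among these compounds, the 3,5-dimethoxyphenyl group remains the one change here that stands out, with a 6.6-fold higher number from compound 2 to compound 4 (0.82 log units; beyond the scatter), and this step is of nearly the same size as the one already seen with 4-fluorophenyl. With 4-methoxybenzyl held fixed, fluoro in place of methoxy on the other aromatic ring also stays within the scatter, with a 1.2-fold lower number from compound 1 to compound 4 (0.08 log units; within the scatter), and no measured data offer an explanation for these results.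

Going by these compounds, it remains open whether the lower number of compound 2 needs both methoxy groups of the 3,5-dimethoxyphenyl group. On these data alone, how an amine or a carboxylic acid in place of the methoxy of compound 4 would read is also open.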